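Chloro on the benzoyl ring: expected half-life of compound 3

This account rests on a few compounds, and the source may have more. Where it says the series, first, only, none or still open, it means among the compounds named here.

Compound 2 `CC(C)(C)c1cc(NC(=O)[C@@H]2CCCCN2C(=O)c2ccccc2)no1` holds the higher of the two numbers in an ADME assay (liver) for metabolic stability, with Liver microsome (Homo sapiens) as the target, read by LC-MS, using microsomes and NADPH, tested at 1 uM (a lower number here means that the compound disappears faster, a higher number that the compound lasts longer), giving 0.683 h, while compound 1 `CC(C)(C)c1cc(NC(=O)[C@@H]2CCCCN2Cc2ccc(Cl)cc2)no1` gives 0.15 h. For the measured compounds named here, the one measured step, a 4.6-fold higher number from compound 1 to compound 2 (0.66 log units; beyond the scatter), changes the whole group on the ring nitrogen and does not isolate a chlorine. Compound 3 `CC(C)(C)c1cc(NC(=O)[C@@H]2CCCCN2C(=O)c2ccc(Cl)cc2)no1` differs from compound 2 by chloro in place of hydrogen on an aromatic carbon. Going by the values given here, no measured step bears on this change, so no shift beyond the scatter is expected: compound 3 is estimated at 0.8 h, within 0.35 h to 1.8 h. The expected step is a 1.2-fold higher number from compound 2 to compound 3 (0.07 log units; within the scatter).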

Compound 3, half-life: 1.25 h
Compound 3: the middle estimate sits 1.6-fold (0.19 log units) below what was measured, and the stated range covers the measured number.
By their numbers in this assay, from the lowest: compound 1; then compounds 2 and 3 (each within the scatter of the next).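

In this assay, chloro in place of hydrogen on an aromatic carbon, para to a large group, gives a 1.8-fold higher number from compound 2 to compound 3 (0.26 log units; within the scatter) and so shows that this position takes a chlorine without a loss in half-life. With chlorine now present on both sides, (4-chlorophenyl)carbonyl in place of 4-chlorobenzyl on the ring nitrogen gives an 8.3-fold higher number from compound 1 to compound 3 (0.92 log units; beyond the scatter) and so shows this change free of the chlorine that the earlier step also altered. Nothing available explains either step. Going by these compounds, whether fluoro, methoxy or a nitrile at this position would read the same remains open, as does the effect of chloro placed elsewhere on this ring.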